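Hydroxyethyl isomers on the shared core

The source may report more compounds than this note shows. Statements on the series, on what has been measured and on what is new or still open speak of the compounds shown alone.

Of the compounds shown here, two on the shared core have been measured so far. In a functional assay on COLO357 cells (Homo sapiens) for cytotoxicity, read by MTT assay, with a stated time of 72 h (on this read-out higher numbers stand for weaker inhibition and lower numbers for stronger inhibition), compound 1 `COc1cc2c(c(OC)c1OC)-c1cc3cc(CO)oc3cc1C(O)CC2` gives 16 nM and compound 2 `COc1cc2c(c(OC)c1OC)-c1cc3cc(C(C)O)oc3cc1C(O)CC2` gives 64 nM, so compound 2 holds the higher of the two numbers, meaning the weaker inhibition.

The next compound, compound 3 `COc1cc2c(c(OC)c1OC)-c1cc3cc(CCO)oc3cc1C(O)CC2`, has the same atoms as compound 2, joined differently: 2-hydroxyethyl in place of 1-hydroxyethyl on an aromatic carbon. It carries 2-hydroxyethyl in place of 1-hydroxyethyl on an aromatic carbon of the five-membered aromatic ring with 1 oxygen, next to the ring oxygen.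

For the measured compounds named here, only one measured step bears on this change: a 4.0-fold higher number from compound 1 to compound 2 (0.60 log units; beyond the scatter), a modest step beyond the scatter, seen with methyl in place of hydrogen on the chain carbon that carries the oxygen. Compound 3 has no such methyl on that carbon, so a partial return towards compound 1 in this assay is expected. Going by the values given here, no measured compound shows the effect of the longer chain, which keeps this expectation loose.

The estimated step is a 2.3-fold lower number from compound 2 to compound 3 (0.36 log units; beyond the scatter), a small move to a lower number. For compound 3 the expected value is 28 nM, with an estimated range of 10 nM to 85 nM.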

Compound 3, half-maximal inhibitory concentration: > 400 nM
Compound 3: no number, only a limit (the forecaster's own chance of this, stated with the estimate: 1%); middle value at least 14-fold (1.15 log units) away from the limit.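

For compound 3, the result in this assay is a limit and not a number: the limit of > 400 nM in this assay, at which 1 of the 3 values shown sits.

Read against the two earlier compounds, this gives an at least 6.2-fold higher number from compound 2 to compound 3 (0.79 log units; beyond the scatter), and, against the hydroxymethyl compound, an at least 25-fold higher number from compound 1 to compound 3 (1.39 log units; beyond the scatter). Compounds 1 and 2 showed only that a methyl on the chain carbon carrying the oxygen costs a modest step; compound 3 adds that at this position, on an aromatic carbon next to the ring oxygen, the arrangement of the side chain matters as well as its atoms, since 1-hydroxyethyl and 2-hydroxyethyl have the same atoms yet only the former gives a number here.

On these data alone, the series leaves open whether the loss with 2-hydroxyethyl follows from the longer distance to the hydroxy group or from the longer chain as such, and the size of the loss stays unknown while compound 3 rests on a limit. A methoxymethyl group, an aminomethyl group or a carboxylic acid at this place would show how far the hydroxy group itself counts, and a 3-hydroxypropyl chain would show whether further lengthening changes the picture.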